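The source may report more compounds than this note shows. Statements on the series, on what has been measured and on what is new or still open speak of the compounds shown alone.

Two compounds have been measured in a functional assay on HT-29 cells (Homo sapiens) for antiproliferative activity, read by MTT assay, with a stated time of 24 h; on this read-out lower numbers stand for stronger inhibition and higher numbers for weaker inhibition:
Compound 1, `COc1ccc(C(=O)/C=C/c2cccc([N+](=O)[O-])c2)c2c1C=CC(C)(C)O2`, gives 4260 nM in this assay.
Compound 2, `COc1ccc(C(=O)/C=C/c2ccc(C(F)(F)F)cc2)c2c1C=CC(C)(C)O2`, gives only the limit > 10000 nM, which is a bound of the measurement and not a number.

Among the measured compounds shown here, compound 2 therefore stands at the limit of > 10000 nM in this assay, at which 1 of the 2 values shown sits, and of the two values shown it is the one that returns no number. The unmeasured compound 3, `COc1ccc(C(=O)/C=C/c2ccccc2)c2c1C=CC(C)(C)O2`, differs from compound 2 in one place: hydrogen in place of trifluoromethyl on an aromatic carbon. For the measured compounds named here, no step between two measured compounds is available to gauge this change, so what can be said rests on the two values alone: compound 1 returns a number, compound 2 only a limit. The expected step is an at least 1.2-fold lower number from compound 2 to compound 3 (0.09 log units; that floor lies within the scatter), modest and toward stronger inhibition, with a real chance that again only a limit is reported. Compound 3 is estimated at 8000 nM, in the range 3000 nM to 25000 nM.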

Compound 3, half-maximal inhibitory concentration: > 10000 nM
Compound 3: no number, only a limit; the forecaster's own chance of this, stated with the estimate: 40%; middle value at least 1.2-fold (0.09 log units) away from the limit.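

In this assay compound 3, which carries hydrogen in place of trifluoromethyl, gives only a limit (> 10000 nM) and no number, so taking trifluoromethyl off this aromatic carbon does not yield a measurable value. The size of the change between compound 2 and compound 3 cannot be read, because both compounds rest on the same limit: the limit of > 10000 nM in this assay, at which 2 of the 3 values shown sit. Among the compounds shown here, the one step that can be read is an at least 2.3-fold higher number from compound 1 to compound 3 (0.37 log units; beyond the scatter) with hydrogen in place of nitro; it lies beyond the scatter and leaves compound 1, which carries nitro, on the side of stronger inhibition, and compound 1 is the only one of the three to return a number.

From the compounds shown here alone, how far compound 2 and compound 3 lie past the limit stays open, and so does any difference between them. Also open, going by these compounds, is whether an amine, a nitrile or a carboxylic acid in place of trifluoromethyl or nitro on the shared core would return a number in this assay and how it would stand against compound 1.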